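Shortening the side chain and ringing the amide in a melatonin ligand

The source may report more compounds than this note shows. Statements on the series, on what has been measured and on what is new or still open speak of the compounds shown alone.

Compound 1 `CCC(=O)NCCC1CCc2ccccc2N1Cc1ccccc1` binds in an assay on CHO cells for displacement of a labelled ligand from melatonin receptor type 1A (Homo sapiens), with a stated time of 120 min (a lower number here means a stronger inhibitor, a higher number a weaker inhibitor), with a value of 326 nM, the higher of the two values recorded here. Compound 2 `CCC(=O)NCC1CCc2c(cccc2OC)N1` gives 57 nM in this assay, a gap that lies beyond the scatter, though the two differ in more than one place. Compound 3 `O=C(NCC1CCc2ccccc2N1Cc1ccccc1)C1CCC1` carries the change ((cyclobutylcarbonyl)amino in place of (propanoylamino)methyl on a saturated chain carbon bound to a saturated ring carbon). For the measured compounds named here, with no step between measured compounds to lean on, compound 3 is expected to lie close to compound 1, a step of a 1.3-fold lower number from compound 1 to compound 3 (0.12 log units; within the scatter) within or just past the scatter in either direction. Compound 3 is therefore estimated at 250 nM, with a range from 60 nM to 1000 nM.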

Compound 3, inhibition constant: 633 nM
The estimate for compound 3 lay 2.5-fold (0.40 log units) below the measured number, and the stated range covers the measured number.
By their numbers in this assay, from the lowest: compound 2; then compounds 1 and 3 (each within the scatter of the next).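

For the compounds shown here, the step of a 1.9-fold higher number from compound 1 to compound 3 (0.29 log units; within the scatter) is the first single-place comparison here: (cyclobutylcarbonyl)amino in place of (propanoylamino)methyl on a saturated chain carbon bound to a saturated ring carbon leaves the number within the scatter. At this position, therefore, a four-membered non-aromatic ring of carbon only can enter without a change beyond the scatter. No measurement shown here explains this result. The compounds shown leave open whether an amine, a carboxylic acid or a longer chain at this position would move the number beyond the scatter.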